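Series notes: phenethyl in place of 2-methoxyphenyl

The source may report more compounds than this note shows. Statements on the series, on what has been measured and on what is new or still open speak of the compounds shown alone.

All numbers below come from an assay on mitochondria (strain BALB/c) for inhibition of glycerol-3-phosphate acyltransferase 1, mitochondrial (Mus musculus), read by scintillation counting, with a stated time of 10 min; a lower number here means a stronger inhibitor, a higher number a weaker inhibitor.

compound 1, `CCCCCCCCS(=O)(=O)Nc1cc(-c2ccc(OC)cc2)ccc1C(=O)O`: 13300 nM
compound 2, `CCCCCCCCS(=O)(=O)Nc1ccc(-c2ccccc2OC)cc1C(=O)O`: 27600 nM
compound 3, `CCCCCCCCS(=O)(=O)Nc1cc(CCc2ccc(OC)cc2)ccc1C(=O)O`: 43000 nM

Compound 2 holds the second highest of the three numbers. Its value and that of compound 3 lie within the scatter of each other, so nothing separates them. Against compound 1 the gap is beyond the scatter: compound 1 gives 13300 nM, compound 2 the higher 27600 nM.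

The next compound is compound 4, `CCCCCCCCS(=O)(=O)Nc1ccc(CCc2ccccc2)cc1C(=O)O`. Relative to compound 2 the change is phenethyl in place of 2-methoxyphenyl on an aromatic carbon.

Among the measured compounds shown here, one measured step bears on this. Between compound 1 and compound 3 the aryl group was likewise extended to an arylethyl group, with the methoxy retained, and this gave a 3.2-fold higher number from compound 1 to compound 3 (0.51 log units; beyond the scatter). For the measured compounds named here, the step to compound 4 adds the loss of the methoxy, and no measured pair here isolates that loss, so its contribution is unknown. Going by the values given here, on the one relevant step alone, a higher number in this assay is expected for compound 4, of modest size, roughly a 2.4-fold higher number from compound 2 to compound 4 (0.37 log units; beyond the scatter).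

The estimate for compound 4 is therefore 65000 nM, with a range from 25000 nM to 170000 nM.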

Compound 4, half-maximal inhibitory concentration: 37500 nM
Estimate against measurement, compound 4: 1.7-fold (0.24 log units) above; the range from low to high includes it.
By their numbers in this assay, from the lowest: compound 1; then compounds 2, 4 and 3 (each within the scatter of the next).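

Working from this assay, replacing 2-methoxyphenyl with phenethyl on this aromatic carbon, meta to a carboxy group and para to a large group, gives a 1.4-fold higher number from compound 2 to compound 4 (0.13 log units; within the scatter), so the two groups cannot be told apart at this place. The earlier aryl-to-arylethyl step, a 3.2-fold higher number from compound 1 to compound 3 (0.51 log units; beyond the scatter), lay beyond the scatter, whereas this one does not, and it also takes away the single hydrogen-bond acceptor of the leaving group; compound 4 therefore goes against any general rule that the longer arylethyl group raises the number in this series. No measurement at hand accounts for the contrast between these two steps.

The step to compound 4 folds two structural differences into one, and the compounds shown leave their separate contributions open, which plain phenyl or 2-(2-methoxyphenyl)ethyl at this place could help to resolve. Also open, on these data alone, is whether an amine or a carboxylic acid on the phenethyl ring would shift the number beyond the scatter.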